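Ether chain change from compound 3 to compound 4

A few compounds are considered here, and "the series" means these few. Any claim that something is new, unique, unknown or untested is made for them only; others in the source may bear on it.

- Compound 1 `CCCCCCOc1ncc(-c2ccccc2OC)n1C`: 43000 nM
- Compound 2 `COc1ccccc1-c1cnc(OC)n1C`: > 100000 nM (a limit of the assay, not a number)
- Compound 3 `C=CCCOc1ncc(-c2ccccc2OC)n1C`: 21000 nM

Among the measured compounds shown here, in a functional assay on SK-MEL-28 cells (Homo sapiens) for inhibition, read by colorimetric assay and MTT assay, with a stated time of 72 h (a higher number here means a weaker inhibitor, a lower number a stronger inhibitor), compound 3 has the lowest number of the series at 21000 nM, and compound 1 is the only other compound with a measured number. Compound 4 `COc1ccccc1-c1cnc(OCCCc2ccccc2)n1C` is still to be measured. The change is benzyl in place of vinyl on a saturated chain carbon, two bonds along the chain from an oxygen on an aromatic ring.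

For the measured compounds named here, the closest precedent is at the same place: a 2.0-fold lower number from compound 1 to compound 3 (0.31 log units; beyond the scatter). Removing the chain altogether gave larger shifts: an at least 2.3-fold higher number from compound 1 to compound 2 (0.36 log units; beyond the scatter) and an at least 4.7-fold lower number from compound 2 to compound 3 (0.67 log units; beyond the scatter). Both of these rest on the limit of compound 2, so their true sizes are open. Going by the values given here, no measured compound carries an aromatic ring on this chain.

Compound 4 keeps an ether chain, so only a small shift is expected, with no firm direction. The estimated change is a 1.2-fold lower number from compound 3 to compound 4 (0.07 log units; within the scatter). For compound 4 the expected value is 18000 nM. The estimated range for compound 4 runs from 6000 nM to 55000 nM.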

Compound 4, half-maximal inhibitory concentration: 4000 nM
Estimate against measurement, compound 4: 4.5-fold (0.65 log units) above; the measured number lies below the stated range.
By their numbers in this assay, from the lowest: compound 4; then compound 3; then compound 1. At a limit, above all of these: compound 2.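

In this assay, this place on the ether chain responds more strongly to an aromatic ring than to the earlier change among open chains: benzyl in place of vinyl gives a 5.3-fold lower number from compound 3 to compound 4 (0.72 log units; beyond the scatter), whereas the earlier change at this place gave a 2.0-fold lower number from compound 1 to compound 3 (0.31 log units; beyond the scatter). Phenyl in place of propyl gives an 11-fold lower number from compound 1 to compound 4 (1.03 log units; beyond the scatter), so compound 4 stands apart from both compounds with an open chain. Phenethyl in place of hydrogen gives an at least 25-fold lower number from compound 2 to compound 4 (1.39 log units; beyond the scatter), a size that is only a bound, since its starting point is a limit of the assay and not a number: the limit of > 100000 nM in this assay, at which 1 of the 4 values shown sits.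

Among the compounds shown here, with only one ring-bearing chain, it remains open whether the shift belongs to the phenyl ring itself or depends on the chain that carries it. A longer chain ending in phenyl, or an amine or carboxylic acid on that ring, would separate these readings.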